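This account rests on a few compounds, and the source may have more. Where it says the series, first, only, none or still open, it means among the compounds named here.

Working notes on the series. The shared core carries a 2-fluorobenzyl group in each member; compound 1 `Cc1coc(-c2nn(Cc3ccccc3F)c3ncccc23)n1` and compound 2 `Cc1oc(-c2nn(Cc3ccccc3F)c3ncccc23)nc1CO` bear oxazole substituents, while compound 3 `CC(C)c1cnc(-c2nn(Cc3ccccc3F)c3ncccc23)nc1N` bears an aminopyrimidine. In a functional assay (aorta) with Oryctolagus cuniculus as the target (on this read-out lower numbers stand for stronger inhibition and higher numbers for weaker inhibition), compound 1 gives 1200 nM and compound 2 gives 1500 nM; the step of a 1.3-fold higher number from compound 1 to compound 2 (0.10 log units; within the scatter) is within the scatter. Compound 3 gives 207000 nM and so stands highest of the three numbers, far beyond the scatter from both others. Compound 4 `CCCS(=O)(=O)c1cnc(-c2nn(Cc3ccccc3F)c3ncccc23)nc1N` differs from compound 3 by propylsulfonyl in place of isopropyl on an aromatic carbon. Within the data shown here, no measured step touches this position or this kind of exchange; the only step known, from one oxazole to another, does not bear on it. The expectation for compound 4 is therefore anchored on compound 3 alone, with a wide range: an estimated step of a 2.1-fold lower number from compound 3 to compound 4 (0.32 log units; beyond the scatter), giving an estimated 100000 nM in this assay, between 10000 nM and 400000 nM.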

Compound 4, half-maximal inhibitory concentration: 378000 nM
Beside the measured number, compound 4's estimate is 3.8-fold (0.58 log units) below it; the measured number falls inside the stated range.
By their numbers in this assay, from the lowest: compounds 1 and 2 (each within the scatter of the next); then compounds 3 and 4 (each within the scatter of the next).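

In this assay, propylsulfonyl in place of isopropyl on this aromatic carbon, ortho to an amino group, gives a 1.8-fold higher number from compound 3 to compound 4 (0.26 log units; within the scatter). At this position, then, a group of 6 heavy atoms with 2 hydrogen-bond acceptors and one of 3 heavy atoms with none give numbers that cannot be told apart. Nothing available offers an explanation for this result.

From the compounds shown here alone, it remains open whether a carboxylic acid or an amine on this carbon would give a number beyond the scatter from compound 3. Going by these compounds, a longer chain on the sulfonyl group is equally open.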